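Swapping the aryl group on a bromoacrylamide core

This account rests on a few compounds, and the source may have more. Where it says the series, first, only, none or still open, it means among the compounds named here.

In a functional assay on L1210 cells (Mus musculus) for inhibition, read by cell counting, with a stated time of 2 days (on this read-out lower numbers stand for stronger inhibition and higher numbers for weaker inhibition), three compounds that share one core and differ only in the group attached to the five-membered ring have been measured. Compound 1 `C=C(Br)C(=O)Nc1cccc(-c2cn3nc(-c4ccc(CC)cc4)sc3n2)c1` carries a 4-ethylphenyl group and gives 2200 nM. Compound 2 `C=C(Br)C(=O)Nc1cccc(-c2cn3nc(Cc4cccc(OC)c4)sc3n2)c1` carries a 3-methoxybenzyl group and gives 2000 nM. Compound 3 `C=C(Br)C(=O)Nc1cccc(-c2cn3nc(-c4ccc(OC)c(OC)c4)sc3n2)c1` carries a 3,4-dimethoxyphenyl group and gives 42 nM, the lowest of the three numbers; the steps of a 52-fold lower number from compound 1 to compound 3 (1.72 log units; beyond the scatter) and a 48-fold lower number from compound 2 to compound 3 (1.68 log units; beyond the scatter) are both far beyond the scatter, while a 1.1-fold lower number from compound 1 to compound 2 (0.04 log units; within the scatter) is within it.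

Compound 4 `C=C(Br)C(=O)Nc1cccc(-c2cn3nc(-c4ccc(Cl)cc4)sc3n2)c1` is not yet measured. It differs from compound 3 by 4-chlorophenyl in place of 3,4-dimethoxyphenyl on an aromatic carbon. The two measured steps that bear on this change both show that replacing 3,4-dimethoxyphenyl with a group lacking the two oxygen acceptors raises the number greatly. The entering 4-chlorophenyl group resembles the 4-ethylphenyl group of compound 1 in carrying no acceptor, so a large step upward in this assay is expected, of the size a 36-fold higher number from compound 3 to compound 4 (1.55 log units; beyond the scatter). Compound 4 is therefore estimated at 1500 nM, with a range from 300 nM to 6000 nM, returning close to the number seen for compound 1.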

Compound 4, half-maximal inhibitory concentration: 1400 nM
The estimate for compound 4 lay 1.1-fold (0.03 log units) above the measured number; low and high end bracket the measured number.
By their numbers in this assay, from the lowest: compound 3; then compounds 4, 2 and 1 (each within the scatter of the next).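

Moving from the 3,4-dimethoxyphenyl group to the 4-chlorophenyl group in this assay gives a 33-fold higher number from compound 3 to compound 4 (1.52 log units; beyond the scatter), so the low number of compound 3 is now lost with a third, different group at this position. The new compound also shows that very different groups here can read alike: chloro in place of ethyl gives a 1.6-fold lower number from compound 1 to compound 4 (0.20 log units; within the scatter), and 4-chlorophenyl in place of 3-methoxybenzyl gives a 1.4-fold lower number from compound 2 to compound 4 (0.15 log units; within the scatter), both within the scatter, so compound 3 alone stands apart from the other three. Nothing measured here explains why this one group differs so much from the others.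

Going by these compounds, it remains open whether both methoxy groups are needed, a question that a 4-methoxyphenyl or a 3-methoxyphenyl group at the same position would address. Also open, on these data alone, is whether the oxygen atoms matter at all, which a 3,4-dimethylphenyl group, with a methyl in place of each methoxy, would help to settle.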